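Replacing the thiophene of compound 2 with an open chain

The source may hold more compounds than are shown below. What is called first, only, known or untested is meant among the compounds shown, and "the series" means these compounds.

Of the compounds shown here, three built on one shared core have been measured: compound 1 `Cc1ncc(-c2ccccc2NCC2=NCCN2)o1`, compound 2 `Cc1ccsc1-c1ccccc1NCC1=NCCN1` and compound 3 `Nc1nccc(-c2ccccc2NCC2=NCCN2)n1`. In a functional assay for activation of Alpha-1A adrenergic receptor (Homo sapiens), read by calcium flux (on this read-out lower numbers stand for an effect already at smaller amounts and higher numbers for an effect only at larger amounts of compound), compound 1 gives 110 nM, compound 2 gives 0.851 nM and compound 3 gives 42.7 nM. Compound 2 therefore stands lowest of the three, with compound 3 nearest and compound 1 furthest, both gaps beyond the scatter. For the measured compounds named here, the one measured step between neighbours is a 130-fold lower number from compound 1 to compound 2 (2.11 log units; beyond the scatter), where a 3-methylthiophen-2-yl replaces a 2-methyl-1,3-oxazol-5-yl on an aromatic carbon.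

Compound 4 `CCO/N=C(\C)c1ccccc1NCC1=NCCN1` takes compound 2 one step further: a group of 6 heavy atoms (4 carbon, 1 nitrogen, 1 oxygen; no ring) in place of a group of 6 heavy atoms (5 carbon, 1 sulfur; one five-membered aromatic ring with 1 hetero atom), on an aromatic carbon. The measured step swapped one five-membered ring for another; here the ring is lost altogether, so that step guides only loosely. Both other ring variants gave far higher numbers than compound 2, so the expectation is a rise, estimated as a 24-fold higher number from compound 2 to compound 4 (1.37 log units; beyond the scatter). For compound 4 in this assay the expected value is 20 nM, within a range from 3 nM to 150 nM.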

Compound 4, half-maximal effective concentration: 52.5 nM
For compound 4 the middle estimate is 2.6-fold (0.42 log units) below the measured one; the measured number falls inside the stated range.
By their numbers in this assay, from the lowest: compound 2; then compounds 3 and 4 (each within the scatter of the next); then compound 1.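

In this assay, taking the ring away from this position gives a 62-fold higher number from compound 2 to compound 4 (1.79 log units; beyond the scatter) and so costs a large part of what the 3-methylthiophen-2-yl group achieves. The same open chain nevertheless gives a 2.1-fold lower number from compound 1 to compound 4 (0.32 log units; beyond the scatter) when set against the 2-methyl-1,3-oxazol-5-yl group, a modest step but beyond the scatter, so among these compounds a ring at this place is not enough on its own to give a low number. No measurement offered here explains either step.

The compounds shown leave open whether the low number of compound 2 depends on the sulfur atom or on the methyl group of its ring, which a phenyl or a 2-methylphenyl group at this place could help to separate. They also leave open how a shorter open chain, such as a methoxy group, or a longer one would compare with compound 4 here.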